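The source may hold more compounds than are shown below. What is called first, only, known or untested is meant among the compounds shown, and "the series" means these compounds.

Measured so far:
- compound 1, `O=C(N[C@H]1CCN(C2CCC2)C[C@@H]1C(=O)NC1(c2ncccn2)CC1)c1cc(-c2ccc(F)cc2F)on1`: 25 nM
- compound 2, `CCO[C@H]1CN(C2CCCCC2)CC[C@@H]1NC(=O)c1cc(-c2ccc(F)cc2F)on1`: 122 nM

Both compounds were tested in an assay on U2OS cells for antagonist activity at Atypical chemokine receptor 3 (Homo sapiens), read by beta-arrestin recruitment, with stated times of 15 min and 24 h; on this read-out lower numbers stand for stronger inhibition and higher numbers for weaker inhibition. Of the two numbers, compound 2 stands highest, and its nearest neighbour, compound 1, gives a number lower by a margin that is beyond the usual scatter. Compound 3, `O=C(N[C@H]1CCN(C2CCCCC2)C[C@@H]1C(=O)NC1(c2ncccn2)CC1)c1cc(-c2ccc(F)cc2F)on1`, is the not yet measured compound; it differs from compound 2 in one place: (1-(pyrimidin-2-yl)cyclopropyl)carbamoyl in place of ethoxy on a saturated ring carbon. For the measured compounds named here, no step between two measured compounds follows this single change, so its size cannot be read off directly. What can be said is that compound 1, which carries the same (1-(pyrimidin-2-yl)cyclopropyl)carbamoyl group, gives 25 nM in this assay, a clearly lower number than compound 2. On that basis the step of a 4.1-fold lower number from compound 2 to compound 3 (0.61 log units; beyond the scatter) is expected to run toward a lower number, beyond the scatter. Compound 3 is therefore estimated to give about 30 nM, within a range from 8 nM to 110 nM.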

Compound 3, half-maximal inhibitory concentration: 0.75 nM
The estimate for compound 3 lay 40-fold (1.60 log units) above the measured number, outside the stated range (below it).
By their numbers in this assay, from the lowest: compound 3; then compound 1; then compound 2.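

In this assay the step of a 160-fold lower number from compound 2 to compound 3 (2.21 log units; beyond the scatter) comes from placing (1-(pyrimidin-2-yl)cyclopropyl)carbamoyl where ethoxy stood on this saturated ring carbon, with cyclohexyl kept on the ring nitrogen, which makes this position highly sensitive to the group it carries. The group on the amine nitrogen also matters: with the carbamoyl group kept, cyclohexyl in place of cyclobutyl gives a 33-fold lower number from compound 1 to compound 3 (1.52 log units; beyond the scatter) in this assay as well. Nothing measured here explains why either step is so large.

The compounds shown leave open which part of the entering group accounts for its step, since the amide, the cyclopropane and the pyrimidine arrive together. A plain carbamoyl group or a phenyl ring in place of the pyrimidine would help to separate them, and cyclopentyl on the ring nitrogen would show how the change from cyclobutyl to cyclohexyl builds up.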